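A Larger Group in Place of Vinyl

The source may report more compounds than this note shows. Statements on the series, on what has been measured and on what is new or still open speak of the compounds shown alone.

In a functional assay on KG-1 cells (Homo sapiens) for antiproliferative activity, read by CCK-8 assay, with a stated time of 72 h (on this read-out lower numbers stand for stronger inhibition and higher numbers for weaker inhibition), compound 1 (`C=CC(=O)Nc1ccc(-n2nc3c(=O)[nH]nc(N)c3c2-c2oc3ccc(Cl)cc3c2C)cc1`) gives < 0.3 nM, which is a limit of the assay and not an exact number. Compound 2 (`Cc1c(-c2c3c(N)n[nH]c(=O)c3nn2-c2ccccc2)oc2ccccc12`) gives 1110 nM, a far larger number and therefore far weaker inhibition. On these two values, compound 1 stands at the strong end of the scale.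

Compound 3 (`Cc1c(-c2c3c(N)n[nH]c(=O)c3nn2-c2ccc(NC(=O)/C=C/CN(C)C)cc2)oc2ccc(Cl)cc12`) keeps the core of compound 1 and changes one place. It carries 3-(dimethylamino)prop-1-en-1-yl in place of vinyl on a carbonyl carbon. The rest of the structure stays the same.

Within the data shown here, no measured pair here shows what this exchange does, so the expectation has only one starting point. That starting point is compound 1, and its < 0.3 nM is only a limit. The expected change is an at least 2.0-fold higher number from compound 1 to compound 3 (0.30 log units; that floor lies within the scatter), a small move towards weaker inhibition that may not rise beyond the usual scatter. For compound 3, the estimated value in this assay is 0.6 nM, with an expected range from 0.1 nM to 5 nM.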

Compound 3, half-maximal inhibitory concentration: 3.7 nM
The estimate for compound 3 lay 6.2-fold (0.79 log units) below the measured number, within the range that was stated.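

In this assay, putting 3-(dimethylamino)prop-1-en-1-yl in place of vinyl on the carbonyl carbon gives an at least 12-fold higher number from compound 1 to compound 3 (1.09 log units; beyond the scatter). Among these compounds, this is the first direct reading of a change at this position, and it shows that the position responds clearly to this exchange, yet compound 3 still gives 3.7 nM, so the larger group does not abolish antiproliferative activity in these cells. Compound 1 sits at a limit of the assay and not at an exact number, so the step gives only a floor and the true gap may be wider: the limit of < 0.3 nM in this assay, at which 1 of the 3 values shown sits.

The compounds shown cannot separate the effect of the longer chain from that of its amine, as a plain prop-1-en-1-yl group without the dimethylamino end would be needed to tell the two apart. On these data alone, it also remains open how other amines at the end of the chain, such as a piperidine or a morpholine, or a saturated chain in place of the double bond, would read in this assay.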